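A Benzodioxin Amide Replaces the Cyanophenyl Group

The source may hold more compounds than are shown below. What is called first, only, known or untested is meant among the compounds shown, and "the series" means these compounds.

Values in a functional assay on SH-SY5Y cells (Homo sapiens) for inhibition, read by sulforhodamine B assay (on this read-out lower numbers stand for stronger inhibition and higher numbers for weaker inhibition), for the three measured compounds:
Compound 1 `COC(=O)CC/C(C)=C/Cc1c(OC)c(C)c2c(c1OCC#CCN1CCN(c3ccc(C#N)cc3)CC1)C(=O)OC2` gives 37800 nM
Compound 2 `COC(=O)CC/C(C)=C/Cc1c(OC)c(C)c2c(c1OCC#CCN1CCN(C(c3ccc(F)cc3)c3ccc(F)cc3)CC1)C(=O)OC2` gives 25800 nM
Compound 3 `COC(=O)CC/C(C)=C/Cc1c(OC)c(C)c2c(c1OCC#CCN1CCN(C(c3ccccc3)c3ccc(Cl)cc3)CC1)C(=O)OC2` gives 9900 nM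

Compound 1 holds the highest of these three numbers, which marks the weakest inhibition on paper, though its gap to compound 2 lies within the scatter. Its gap to compound 3 lies beyond the scatter. Compound 4 `COC(=O)CC/C(C)=C/Cc1c(OC)c(C)c2c(c1OCC#CCN1CCN(C(=O)C3COc4ccccc4O3)CC1)C(=O)OC2` has not been measured yet. Among the measured compounds shown here, it keeps the core of compound 1 and carries (2,3-dihydro-1,4-benzodioxin-2-yl)carbonyl in place of 4-cyanophenyl on an amine nitrogen in a ring and no measured compound carries this group. For the measured compounds named here, the only guide is the narrow span of the values, from compound 3 (9900 nM) to compound 1 (37800 nM). In this assay no shift beyond the scatter is expected (estimated as a 1.5-fold lower number from compound 1 to compound 4 (0.18 log units; within the scatter)). For compound 4 the estimated value is 25000 nM (expected range 9000 nM to 70000 nM).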

Compound 4, half-maximal inhibitory concentration: > 50000 nM
Compound 4: only a limit was reported; the forecaster's own chance of this, stated with the estimate: 15%; middle value at least 2.0-fold (0.30 log units) from the limit.
By their numbers in this assay, from the lowest: compound 3; then compounds 2 and 1 (each within the scatter of the next). At a limit, above all of these: compound 4.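

In this assay compound 4 gives > 50000 nM, which is a limit of the assay and not a number. Replacing 4-cyanophenyl with (2,3-dihydro-1,4-benzodioxin-2-yl)carbonyl on an amine nitrogen in a ring gives an at least 1.3-fold higher number from compound 1 to compound 4 (0.12 log units; that floor lies within the scatter), so only a floor is known: the true gap may stay within the scatter or be larger. Compound 4 alone among those shown has a carbonyl on this nitrogen, and it shows no gain in inhibition, though the reading only marks where the assay's range ended: the limit of > 50000 nM in this assay, at which 1 of the 4 values shown sits.

Going by these compounds, it remains open whether the carbonyl or the benzodioxin part matters more for this result. A benzoyl group on the same nitrogen, which keeps the carbonyl without the benzodioxin part, or a plain benzyl group could help separate the two.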